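The source may report more compounds than this note shows. Statements on the series, on what has been measured and on what is new or still open speak of the compounds shown alone.

Measured so far in an assay on membranes from CHO cells for displacement of a labelled ligand from adenosine receptor A1 (Homo sapiens), read by scintillation counting, with a stated time of 60 min, tested at 1 uM; a higher number here means more inhibition at the concentration tested (going by the name of the read-out), a lower number less inhibition:
- compound 1 `CCCOC(=O)C1=C(C)NC(=O)NC1c1ccsc1`: 44%
- compound 2 `CC1=C(C(=O)OC2CCC2)C(c2ccsc2)NC(=O)N1`: 40%

Going by the values given here, compound 2 stands at 40% in this assay, and its only neighbour among the measured compounds is compound 1; the step of a number 4 percentage points lower from compound 1 to compound 2 (within the scatter) separates the two, so nothing beyond the scatter distinguishes them.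

Compound 3 `CC1=C(C(=O)OCC2CC2)C(c2ccsc2)NC(=O)N1` is not yet measured. The change from compound 2 to compound 3 is cyclopropylmethyl in place of cyclobutyl on an oxygen next to a carbonyl group.

Among the compounds with values here, only one measured step bears on this change: a number 4 percentage points lower from compound 1 to compound 2 (within the scatter), where the group on the oxygen next to the carbonyl group was altered while the rest of the structure stayed the same, and that step remained within the scatter. The present change again alters the same group, this time without adding or removing any atom, so no step beyond the scatter is expected in this assay, in either direction.

For compound 3 the expected value in this assay is 40%, with a range from 25% to 55%; the expected step is no change at the digits printed from compound 2 to compound 3 (within the scatter).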

Compound 3, a percentage reported as inhibition, at one concentration (the size of the read-out at that concentration, not a potency): 39%
Compound 3: middle estimate off by 1 percentage points, on the high side; measured number inside the range.
By their numbers in this assay, from the lowest: compounds 3, 2 and 1 (each within the scatter of the next).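

In this assay, cyclobutyl and cyclopropylmethyl on an oxygen next to a carbonyl group have the same heavy-atom count but different ring sizes, and exchanging them gives a number 1 percentage points lower from compound 2 to compound 3 (within the scatter), so this rearrangement of the same carbons does not separate the two compounds. The other new comparison, cyclopropyl in place of ethyl on a saturated chain carbon bound to an oxygen next to a carbonyl group, gives a number 5 percentage points lower from compound 1 to compound 3 (within the scatter), so the open propyl chain and both ring-bearing groups now stand within the scatter of one another. No independent data bear on why these three groups read alike.

The compounds shown leave open whether a markedly different group on this oxygen, such as a longer chain ending in an amine or a carboxylic acid, or a phenyl ring, would read apart from these three. From the compounds shown here alone, these are percentages at a single concentration in this assay, so how the three compounds compare as potencies also remains open.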